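Two Chlorines on the Thiophene of a Pyrazoline

The source may report more compounds than this note shows. Statements on the series, on what has been measured and on what is new or still open speak of the compounds shown alone.

Compounds measured in an ADME assay on PBMC cells (Homo sapiens) for cytotoxicity, with a stated time of 5 days; on this read-out lower numbers stand for stronger inhibition and higher numbers for weaker inhibition:
compound 1 `Cc1csc(C(=O)/C=C/c2ccc(N3CCCCC3)cc2)c1` gives 68800 nM.
compound 2 `Cc1ccc(C(=O)/C=C/c2ccc(N3CCCCC3)cc2)s1` gives 77800 nM.
compound 3 `c1cc(C2=NNC(c3ccc(N4CCCCC4)cc3)C2)cs1` gives only an assay limit, > 100000 nM.

Compound 3 stands apart from the other two: its result is a limit and not a number, as the limit of > 100000 nM in this assay, at which 1 of the 3 values shown sits, records. Among the compounds with values here, compounds 1 and 2 share the chalcone-type carbonyl linker, and the one measured step between them, a 1.1-fold higher number from compound 1 to compound 2 (0.05 log units; within the scatter), does not leave the scatter. It concerns a different core and a methyl shift, so it gives no guide to the present change.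

Compound 4 `Clc1cc(C2=NNC(c3ccc(N4CCCCC4)cc3)C2)c(Cl)s1` differs from compound 3 in one place: 2,5-dichlorothiophen-3-yl in place of thiophen-3-yl on a carbon with a double bond to nitrogen. Within the data shown here, no measured step bears on a chlorination of this kind, and compound 3 itself offers only a limit as a starting point. The change is therefore expected to move this assay little, if at all, and the estimated step is an at least 1.2-fold lower number from compound 3 to compound 4 (0.09 log units; that floor lies within the scatter). For compound 4 the expected value in this assay is 80000 nM, with a range from 25000 nM to 250000 nM, and a fair chance that only a limit is reported again.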

Compound 4, half-maximal inhibitory concentration: 59000 nM
For compound 4 the middle estimate is 1.4-fold (0.13 log units) above the measured one, within the range that was stated.
By their numbers in this assay, from the lowest: compounds 4, 1 and 2 (each within the scatter of the next). At a limit, above all of these: compound 3.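

In this assay, 2,5-dichlorothiophen-3-yl in place of thiophen-3-yl on a carbon with a double bond to nitrogen gives an at least 1.6-fold lower number from compound 3 to compound 4 (0.22 log units; that floor lies within the scatter). With the two chlorines in place, compound 4 gives a number on the shared core rather than a limit, so this position now has a measured value on one side of the change. The size of the step can still be read only as a floor, and that floor does not leave the scatter, because the starting point for the change is a limit and not a number: the limit of > 100000 nM in this assay, at which 1 of the 4 values shown sits.

As far as these compounds go, whether one chlorine alone would give the same result remains open, as does the outcome with a methyl, an amine or a carboxylic acid on the thiophene. From the compounds shown here alone, no single change links this core to the carbonyl linker of compound 1 and compound 2, so how the two series compare also stays open.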